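The source may report more compounds than this note shows. Statements on the series, on what has been measured and on what is new or still open speak of the compounds shown alone.

Working notes on the series. In an ADME assay on Caco-2 cells (Homo sapiens) for permeability, in the apical to basolateral direction (a lower number here means that the compound crosses the layer more slowly, a higher number that the compound crosses the layer faster), compound 1 `CCCC(=O)N1CCC(CN(C2Cc3cc(C#N)ccc3N(Cc3cncn3C)C2)S(=O)(=O)c2ccccn2)CC1` gives 0.5 10^-6 cm/s, the second highest of the three numbers in hand. Compound 2 `Cn1cncc1CN1CC(N(Cc2ccc(S(C)(=O)=O)cc2)S(=O)(=O)c2ccccn2)Cc2cc(C#N)ccc21` gives 0.2 10^-6 cm/s, and a 2.5-fold lower number from compound 1 to compound 2 (0.40 log units; beyond the scatter). Compound 3 `Cn1cncc1CN1CC(N(Cc2cccc(-n3cccc3)c2)S(=O)(=O)c2ccccn2)Cc2cc(C#N)ccc21` gives 2.3 10^-6 cm/s, and a 4.6-fold higher number from compound 1 to compound 3 (0.66 log units; beyond the scatter), with a 12-fold higher number from compound 2 to compound 3 (1.06 log units; beyond the scatter) between the other two. Compound 4 `Cn1cncc1CN1CC(N(CC2CCN(C(=O)CC(F)(F)F)CC2)S(=O)(=O)c2ccccn2)Cc2cc(C#N)ccc21` differs from compound 1 at another place entirely: trifluoromethyl in place of ethyl on a saturated chain carbon bound to a carbonyl carbon. Among the compounds with values here, none of the measured steps touches the propylcarbonyl chain, so nothing in hand bears directly on this change; only a step within the scatter, or a slight one, is expected in this assay. Compound 4 is therefore estimated at 0.7 10^-6 cm/s, within 0.3 10^-6 cm/s to 1.6 10^-6 cm/s, which is expected to mean a 1.4-fold higher number from compound 1 to compound 4 (0.15 log units; within the scatter).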

Compound 4, apparent permeability: 0.5 10^-6 cm/s
Compound 4: middle estimate off by 1.4-fold (0.15 log units), on the high side, within the range that was stated.
By their numbers in this assay, from the lowest: compound 2; then compounds 1 and 4 (each within the scatter of the next); then compound 3.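

In this assay, within the data shown here, the exchange of ethyl for trifluoromethyl on a saturated chain carbon bound to a carbonyl carbon gives no change at the digits printed from compound 1 to compound 4 (within the scatter) and provides the first reading at this position, since the earlier steps all replaced the entire group on a saturated chain carbon bound to a sulfonamide nitrogen. No measured evidence in hand explains this result. As far as these compounds go, whether a longer chain such as butyl, or a dimethylamino group, at this place would behave in the same way remains open. Also open, from the compounds shown here alone, is whether this exchange would give a similar step in compound 3, which carries 3-(1H-pyrrol-1-yl)phenyl in place of the acylated piperidine.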